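Swapping trifluoromethyl for benzyloxycarbonyl on compound 2

The source may hold more compounds than are shown below. What is called first, only, known or untested is meant among the compounds shown, and "the series" means these compounds.

Measured in a functional assay on A549 cells (Homo sapiens) for antiproliferative activity, read by MTT assay, with a stated time of 48 h; a lower number here means a stronger inhibitor, a higher number a weaker inhibitor:
- compound 1 `Clc1ccc(-c2nn(-c3ccccc3)cc2-c2nc3cc(Cl)ccc3[nH]2)cc1`: 1340 nM
- compound 2 `FC(F)(F)c1ccc2[nH]c(-c3cn(-c4ccccc4)nc3-c3ccc(Cl)cc3)nc2c1`: 3360 nM

Only these two compounds have been measured so far. Compound 2, at 3360 nM, has the higher number of the pair, which makes it the weaker inhibitor of the two. The next compound to be tested is compound 3 `O=C(OCc1ccccc1)c1ccc2[nH]c(-c3cn(-c4ccccc4)nc3-c3ccc(Cl)cc3)nc2c1`. It keeps the shared core of compound 2 and changes one group: benzyloxycarbonyl in place of trifluoromethyl on an aromatic carbon. In words, benzyloxycarbonyl takes the place of trifluoromethyl on an aromatic carbon.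

Just one measured step bears on this change. Putting trifluoromethyl in place of chloro gave a 2.5-fold higher number from compound 1 to compound 2 (0.40 log units; beyond the scatter), a modest shift. Among the measured compounds shown here, that step says little about benzyloxycarbonyl, since no measured compound carries this group and the direction of any change is therefore open. A step of similar modest size is expected in this assay, in no firm direction, and it may stay within the scatter. The expected step is a 1.1-fold lower number from compound 2 to compound 3 (0.05 log units; within the scatter). For compound 3 the estimate is 3000 nM, with an expected range from 800 nM to 11000 nM.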

Compound 3, half-maximal inhibitory concentration: 7730 nM
Estimate against measurement, compound 3: 2.6-fold (0.41 log units) below; the measured number falls inside the stated range.
By their numbers in this assay, from the lowest: compound 1; then compound 2; then compound 3.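

In this assay, benzyloxycarbonyl in place of trifluoromethyl gives a 2.3-fold higher number from compound 2 to compound 3 (0.36 log units; beyond the scatter) and, in place of chloro, gives a 5.8-fold higher number from compound 1 to compound 3 (0.76 log units; beyond the scatter) on the same shared core. This position therefore accepts a much larger group that brings its own aromatic ring and two hydrogen-bond acceptors, and compound 3 keeps a measurable effect on the cells, although it is the weakest inhibitor of the three. No measured evidence here explains why the number rises with this change.

The compounds shown cannot tell whether the rise follows the benzyl ring, the carbonyl or the overall size of the new group, since all of these enter together. A carboxylic acid, a methyl ester or an amide at this position would help to separate those parts, while a simple amine or a fluorine would show whether anything on this carbon can give a lower number than chloro does.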